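This account rests on a few compounds, and the source may have more. Where it says the series, first, only, none or still open, it means among the compounds named here.

Measured so far, in a functional assay on U2OS cells for antagonist activity at proto-oncogene Wnt-3 (Homo sapiens), read by a luciferase reporter, with a stated time of 18 h; a lower number here means that less compound is needed, a higher number that more compound is needed for the effect:

- compound 1, `CC(C)(C)OC(=O)N1CCC[C@H]1C(=O)N1CCC(NS(=O)(=O)c2cc(S(=O)(=O)c3ccccc3)ccc2C(F)(F)F)CC1`, gives 60 nM
- compound 2, `CN(C)c1ccc(C(=O)N2CCC[C@H]2C(=O)N2CCC(NS(=O)(=O)c3cc(S(=O)(=O)c4ccccc4)ccc3C(F)(F)F)CC2)cc1`, gives 830 nM
- compound 3, `CN(C)C(=O)N1CCC[C@H]1C(=O)N1CCC(NS(=O)(=O)c2cc(S(=O)(=O)c3ccccc3)ccc2C(F)(F)F)CC1`, gives 160 nM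

All three share one core and differ only in the group attached to the nitrogen of the five-membered ring. Among them compound 3 stands second highest of the three numbers: it sits above compound 1 by a 2.7-fold higher number from compound 1 to compound 3 (0.43 log units; beyond the scatter) and below compound 2 by a 5.2-fold lower number from compound 2 to compound 3 (0.71 log units; beyond the scatter), while the widest gap is a 14-fold higher number from compound 1 to compound 2 (1.14 log units; beyond the scatter). Each of these steps swapped one group on a carbonyl carbon and kept the carbonyl itself.

Compound 4, `CC(C)(C)CCN1CCC[C@H]1C(=O)N1CCC(NS(=O)(=O)c2cc(S(=O)(=O)c3ccccc3)ccc2C(F)(F)F)CC1`, has not yet been measured. Its change from compound 3 is 3,3-dimethylbutyl in place of dimethylcarbamoyl on an amine nitrogen in a ring, so here the carbonyl is removed rather than re-decorated. Going by the values given here, none of the measured steps covers that kind of change, which leaves the direction uncertain. The measured steps show that the group at this position matters and that the smallest number came with compound 1, so a modest rise from compound 3 seems more likely than a fall. The expected step for compound 4 is therefore a 2.5-fold higher number from compound 3 to compound 4 (0.40 log units; beyond the scatter). Compound 4 is estimated at 400 nM, within a range of 100 nM to 2000 nM.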

Compound 4, half-maximal effective concentration: 450 nM
Compound 4: middle estimate off by 1.1-fold (0.05 log units), on the low side; the range from low to high includes it.
By their numbers in this assay, from the lowest: compound 1; then compound 3; then compounds 4 and 2 (each within the scatter of the next).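

Replacing dimethylcarbamoyl with 3,3-dimethylbutyl removes the carbonyl from this position, and in this assay that change gives a clear rise (a 2.8-fold higher number from compound 3 to compound 4 (0.45 log units; beyond the scatter)), as does the replacement of tert-butoxycarbonyl by the same chain (a 7.5-fold higher number from compound 1 to compound 4 (0.88 log units; beyond the scatter)). The two lowest numbers therefore belong to compounds with a carbonyl on this nitrogen, but a carbonyl alone does not ensure a low number: compound 2 carries one and cannot be told apart from the chain compound (a 1.8-fold lower number from compound 2 to compound 4 (0.27 log units; within the scatter)). No evidence is available to explain these differences.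

The compounds shown leave open whether a carbon chain of another length, or a chain ending in an amine or a carboxylic acid, would give a number closer to that of compound 3 or compound 4. They also leave open whether a small carbonyl group such as acetyl or methoxycarbonyl would keep the low numbers seen with the tert-butoxycarbonyl and dimethylcarbamoyl groups.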